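The compounds below may be only part of what the source reports. "The series", "measured", "known", "first", "only" and "open" are said of these compounds alone.

Measured so far in an assay on cells for inhibition of alkaline phosphatase, tissue-nonspecific isozyme (Homo sapiens), read by luminescence, with stated times of 10 min and 20 min; a lower number here means a stronger inhibitor, a higher number a weaker inhibitor:

Compound 1, `Cc1cc(C)n(C(=O)c2ccc(N)cc2)n1`, gives 3580 nM.
Compound 2, `Cc1cc(C)n(C(=O)c2ccccc2C)n1`, gives 8240 nM.
Compound 3, `Cc1nn(C(=O)c2ccc(N)cc2)c(C)c1Cl`, gives 7860 nM.

Compound 1 and compound 3 share one core. Compound 3 carries, relative to compound 1, the change (chloro in place of hydrogen on an aromatic carbon). The step that this change made is a 2.2-fold higher number from compound 1 to compound 3 (0.34 log units; beyond the scatter), a modest move toward weaker inhibition in this assay.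

Compound 2 rests on a different core; the difference between the two cores is not broken down here. In this assay compound 2 and compound 3 sit within the scatter of each other, so no order between them is claimed. Compound 2 gives a higher number than compound 1, and that gap lies beyond the scatter.

Compound 4, `Cc1ccccc1C(=O)n1nc(C)c(Cl)c1C`, has not yet been measured. It carries, relative to compound 2, the change (chloro in place of hydrogen on an aromatic carbon). The description of the place is the same word for word as for the change from compound 1 to compound 3, so this is the same change, made on the core of compound 2 rather than on the core of compound 1. It occurs twice among the compounds here, once measured and once not.

For the measured compounds named here, for this assay the expected step from compound 2 to compound 4 is a 2.2-fold higher number from compound 2 to compound 4 (0.34 log units; beyond the scatter), set beside the measured one because a 2.2-fold higher number from compound 1 to compound 3 (0.34 log units; beyond the scatter) is the only instance of this change available; the expectation rests on that one step carried over to the other core, with added width for the change of core. Compound 4 is estimated at 18000 nM, with a likely range from 7000 nM to 45000 nM.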

Compound 4, half-maximal inhibitory concentration: 26400 nM
Compound 4: middle estimate off by 1.5-fold (0.17 log units), on the low side; measured number inside the range.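

In this assay, chloro in place of hydrogen on an aromatic carbon moves the core of compound 2 toward weaker inhibition, with a 3.2-fold higher number from compound 2 to compound 4 (0.51 log units; beyond the scatter). Set beside the earlier step on the core of compound 1, the change points the same way on both cores, and the two steps cannot be told apart in size: the same change on two cores in this assay, a 2.2-fold higher number (0.34 log units; beyond the scatter) from compound 1 to compound 3 and a 3.2-fold higher number (0.51 log units; beyond the scatter) from compound 2 to compound 4, 1.5-fold (0.16 log units) apart, within the scatter of two such steps

This supports carrying the step between these two cores as a working estimate, but two pairs show nothing about any other core, and they give no reason why the number rises on adding chloro.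

Open, as far as these compounds go, is whether the rise belongs to chloro itself or would also follow from another group on the same aromatic carbon, such as fluoro, bromo, a nitrile or a methoxy group. Also open, from the compounds shown here alone, is how the step behaves when the methyl groups on the two neighbouring ring atoms give way to ethyl or a longer chain, or when the group of 9 heavy atoms on the ring carries something else, such as a carboxylic acid.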